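Three Methoxy Groups in Place of One on the Aryl Ring

A few compounds are considered here, and "the series" means these few. Any claim that something is new, unique, unknown or untested is made for them only; others in the source may bear on it.

Going by the values given here, compound 1 `COc1cccc(-n2cc(CO/N=C3\CC[C@]4(C)[C@@H](CC/C=C(\C)CC/C=C(\C)CCC=C(C)C)[C@](C)(O)CC[C@H]4C3(C)C)nn2)c1` stands highest of the two numbers so far in a functional assay on DU-145 cells (Homo sapiens) for cytotoxicity, read by MTT assay, with a stated time of 48 h (on this read-out higher numbers stand for weaker inhibition and lower numbers for stronger inhibition), at 30500 nM. Its nearest neighbour is compound 2 `CC(C)=CCC/C(C)=C/CC/C(C)=C/CC[C@@H]1[C@@]2(C)CC/C(=N\OCc3cn(-c4c(Cl)cc([N+](=O)[O-])cc4Cl)nn3)C(C)(C)[C@@H]2CC[C@@]1(C)O`, which in this assay gives 16400 nM; the step of a 1.9-fold lower number from compound 1 to compound 2 (0.27 log units; within the scatter) lies within the scatter. Compound 3 `COc1cc(OC)c(-n2cc(CO/N=C3\CC[C@]4(C)[C@@H](CC/C=C(\C)CC/C=C(\C)CCC=C(C)C)[C@](C)(O)CC[C@H]4C3(C)C)nn2)c(OC)c1` differs from compound 1 by 2,4,6-trimethoxyphenyl in place of 3-methoxyphenyl on an aromatic nitrogen. Among the compounds with values here, the only measured step at this position, that aryl exchange, stayed within the scatter, and no step exchanges one methoxyphenyl for another. For compound 3 the expected step is therefore a 1.2-fold lower number from compound 1 to compound 3 (0.07 log units; within the scatter), nothing beyond the scatter. Compound 3 is estimated at 26000 nM, between 10000 nM and 70000 nM.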

Compound 3, half-maximal inhibitory concentration: 11100 nM
Compound 3: the middle estimate sits 2.3-fold (0.37 log units) above what was measured; low and high end bracket the measured number.
By their numbers in this assay, from the lowest: compounds 3, 2 and 1 (each within the scatter of the next, the first and the last beyond it).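

Going by these compounds alone, the exchange to 2,4,6-trimethoxyphenyl gives a 2.7-fold lower number from compound 1 to compound 3 (0.44 log units; beyond the scatter) in this assay and is the first step on this aromatic nitrogen to pass the scatter, showing that the aryl group here can shift the number, if only modestly. Set against 2,6-dichloro-4-nitrophenyl, the same group gives a 1.5-fold lower number from compound 2 to compound 3 (0.17 log units; within the scatter), so these two aryl groups cannot be told apart. Nothing measured here accounts for the shift. The compounds shown leave open whether the count of methoxy groups matters, and whether an aryl ring carrying an amine or a carboxylic acid would move the number at all.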